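Replacing Trifluoromethyl with Methoxy on the Pendant Phenyl Ring

This account rests on a few compounds, and the source may have more. Where it says the series, first, only, none or still open, it means among the compounds named here.

Measured compounds:
Compound 1, `COc1cc2c(Oc3ccc(NC(=O)c4cc(-c5ccccc5C)ccn4)cc3F)ccnc2cc1OCCCN1CCN(C)CC1`, gives 240 nM in a functional assay on MKN-45 cells (Homo sapiens) for cytotoxicity, read by MTT assay, with a stated time of 72 h; on this read-out lower numbers stand for stronger inhibition and higher numbers for weaker inhibition.
Compound 2, `COc1cc2c(Oc3ccc(NC(=O)c4cc(-c5ccc(C(F)(F)F)cc5)ccn4)cc3F)ccnc2cc1OCCCN1CCN(C)CC1`, gives 330 nM in this assay.

Compound 2 carries the higher of the two numbers, but the gap to compound 1 is small: a 1.4-fold higher number from compound 1 to compound 2 (0.14 log units; within the scatter). The two compounds therefore cannot be told apart on this read-out.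

Compound 3, `COc1ccc(-c2ccnc(C(=O)Nc3ccc(Oc4ccnc5cc(OCCCN6CCN(C)CC6)c(OC)cc45)c(F)c3)c2)cc1`, keeps the whole shared core of compound 2 and differs only at one spot: methoxy in place of trifluoromethyl on an aromatic carbon.

Within the data shown here, no measured step covers this exact change. Among the measured compounds shown here, the one step that exists, a 1.4-fold higher number from compound 1 to compound 2 (0.14 log units; within the scatter), swaps a different substituent on the same pendant ring and stays within the scatter, which hints that this ring tolerates variation. On that thin basis no shift beyond the scatter is expected, and the step expected is a 1.1-fold lower number from compound 2 to compound 3 (0.04 log units; within the scatter). Compound 3 is estimated at 300 nM, within 120 nM to 800 nM.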

Compound 3, half-maximal inhibitory concentration: 250 nM
For compound 3 the middle estimate is 1.2-fold (0.08 log units) above the measured one, and the stated range covers the measured number.
By their numbers in this assay, from the lowest: compounds 1, 3 and 2 (each within the scatter of the next).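

In this assay putting methoxy in place of trifluoromethyl on the pendant phenyl ring gives a 1.3-fold lower number from compound 2 to compound 3 (0.12 log units; within the scatter) and so leaves no readable mark on the number, even though the entering group carries a hydrogen-bond acceptor and the leaving group carries none. Set against the 2-methylphenyl group, the 4-methoxyphenyl group gives a 1.0-fold higher number from compound 1 to compound 3 (0.02 log units; within the scatter) and so adds a third group to the set, with all three compounds now within the scatter of one another. Nothing measured here offers an explanation for this flat result.

As far as these compounds go, whether the flatness extends beyond these three groups remains open, since an amine, a carboxylic acid or a longer chain on this ring could behave differently. The compounds shown also cannot say whether any change at this spot would move the number beyond the scatter.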